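The compounds below may be only part of what the source reports. "The series", "measured", "known", "first", "only" and "open" are said of these compounds alone.

Measured in a functional assay on NCI-H460 cells (Homo sapiens) for cytotoxicity, read by MTT assay, with a stated time of 96 h (a lower number here means a stronger inhibitor, a higher number a weaker inhibitor), so far:
compound 1 `COCCOc1cc(-c2cnc(OC)c(NS(=O)(=O)c3ccc(F)cc3F)c2)cc2c(C)nc(N)nc12` at 200 nM
compound 2 `COc1ncc(-c2cc(OC3CCC(F)(F)CC3)c3nc(N)nc(C)c3c2)cc1NS(=O)(=O)c1ccc(F)cc1F` at 83 nM
compound 3 `COc1ncc(-c2cc(OC3CCOCC3)c3nc(N)nc(C)c3c2)cc1NS(C)(=O)=O` at 860 nM

Compound 3 has the highest number of the three and lies beyond the scatter from both others. The next compound, compound 4 `COc1ncc(-c2cc(OC3CCOCC3)c3nc(N)nc(C)c3c2)cc1NS(=O)(=O)c1ccc(F)cc1Cl`, differs from it by 2-chloro-4-fluorophenyl in place of methyl on a sulfonyl sulfur and is otherwise unchanged: 2-chloro-4-fluorophenyl in place of methyl on a sulfonyl sulfur.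

Among the compounds with values here, the one measured step, a 2.4-fold lower number from compound 1 to compound 2 (0.38 log units; beyond the scatter), is modest and concerns the group on the oxygen, not the sulfonyl sulfur. It therefore gives only a sense of how far that other position moves the number. The closest evidence is indirect: compound 1 at 200 nM and compound 2 at 83 nM both carry a fluorinated phenyl ring on the sulfonyl sulfur, but both also differ from compound 3 on the oxygen. Within the data shown here, no measured pair isolates the change.

A lower number is still expected in this assay, beyond the scatter. The expected size is a 6.6-fold lower number from compound 3 to compound 4 (0.82 log units; beyond the scatter), with wide uncertainty. The estimate for compound 4 is 130 nM, with an expected range from 45 nM to 400 nM.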

Compound 4, half-maximal inhibitory concentration: 17 nM
For compound 4 the middle estimate is 7.6-fold (0.88 log units) above the measured one, and the stated range ends above it.
By their numbers in this assay, from the lowest: compound 4; then compound 2; then compound 1; then compound 3.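

With all else held constant, the sulfonyl sulfur can now be read on its own: in this assay, 2-chloro-4-fluorophenyl in place of methyl gives a 51-fold lower number from compound 3 to compound 4 (1.70 log units; beyond the scatter), a large step. Within the data shown here, the only other single-place step, a 2.4-fold lower number from compound 1 to compound 2 (0.38 log units; beyond the scatter), is modest and sits on the oxygen, so within this small set the sulfonyl position shows the greater reach. Nothing measured here bears on why the number falls at this position.

Open, on these data alone, is how much of the step belongs to the ring itself and how much to the chlorine and fluorine, a question that an unsubstituted phenyl or a longer chain such as n-butyl on the sulfonyl sulfur would address. Also open, as far as these compounds go, is whether the step carries over to compounds with 2-methoxyethyl or 4,4-difluorocyclohexyl on the oxygen.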